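Fluorine pattern on the benzyl arm of the shared core

The source may report more compounds than this note shows. Statements on the series, on what has been measured and on what is new or still open speak of the compounds shown alone.

Measured so far in an assay on FRT cells for positive allosteric modulation of Cystic fibrosis transmembrane conductance regulator variant N1303K (Homo sapiens), in the presence of a further agent that is not named here; a higher number here means that more compound is needed for the effect, a lower number that less compound is needed:
- compound 1 `COc1ccc2[nH]c3c(c2c1)CCNC31CCN(Cc2ccc(Br)c(F)c2)CC1`: 1800 nM
- compound 2 `COc1ccc2[nH]c3c(c2c1)CCNC31CCN(Cc2cc(F)c(F)c(F)c2)CC1`: 2600 nM
- compound 3 `COc1ccc2[nH]c3c(c2c1)CCNC31CCN(Cc2ccc(F)c(F)c2)CC1`: 11000 nM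

Compound 3 carries the highest number of the three; the gaps to compound 2 and compound 1 are a 4.2-fold higher number from compound 2 to compound 3 (0.63 log units; beyond the scatter) and a 6.1-fold higher number from compound 1 to compound 3 (0.79 log units; beyond the scatter), both beyond the scatter. Compound 4 `COc1ccc2[nH]c3c(c2c1)CCNC31CCN(Cc2cc(F)c(F)cc2F)CC1` differs from compound 3 by fluoro in place of hydrogen on an aromatic carbon. The step that bears on it is a 4.2-fold higher number from compound 2 to compound 3 (0.63 log units; beyond the scatter), where removing a fluoro from a trifluorophenyl raised the number; read backwards, adding a fluoro lowered it, though the fluoro there sat in a different place. A modest lowering is therefore expected, a 2.2-fold lower number from compound 3 to compound 4 (0.34 log units; beyond the scatter), and compound 4 is estimated at 5000 nM, within 1800 nM to 14000 nM.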

Compound 4, half-maximal effective concentration: 600 nM
Beside the measured number, compound 4's estimate is 8.3-fold (0.92 log units) above it, outside the stated range (below it).
By their numbers in this assay, from the lowest: compound 4; then compounds 1 and 2 (each within the scatter of the next); then compound 3.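

Placing a fluoro on the aromatic carbon ortho to a large group gives the largest step in the series, an 18-fold lower number from compound 3 to compound 4 (1.26 log units; beyond the scatter) on going from 3,4-difluorobenzyl to 2,4,5-trifluorobenzyl. The fluorine count alone does not set the number, since moving to the 2,4,5-trifluorophenyl arm gives a 4.3-fold lower number from compound 2 to compound 4 (0.64 log units; beyond the scatter) at the same count. The same arm also improves on the bromo-bearing arm, with a 3.0-fold lower number from compound 1 to compound 4 (0.48 log units; beyond the scatter) as the step. Nothing available accounts for this positional preference.

Still open, as far as these compounds go, is whether this gain depends on the other two fluoro groups. It is also unknown whether a chloro, methyl or methoxy on that carbon would serve equally well.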